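A larger group in place of a hydroxy group

The compounds below may be only part of what the source reports. "The series", "measured", "known", "first", "only" and "open" are said of these compounds alone.

Of the compounds shown here, two have so far been measured in an assay on isolated protein for inhibition of ubiquitin carboxyl-terminal hydrolase 7 (Homo sapiens), read by fluorescence, with stated times of 30 min and 1 h; a higher number here means a weaker inhibitor, a lower number a stronger inhibitor. Compound 1 `Cc1cc(Cl)cc(-c2ccnc3cc(CN4C(=O)CCC4=O)sc23)c1O[C@H]1C[C@H](N)C1` gives 3.4 nM. Compound 2 `O=C([C@H]1Cc2cc(Cl)cc(-c3ccnc4cc(CO)sc34)c2O1)N1CCNCC1` gives 43 nM, the higher of the two numbers, and the gap to compound 1 lies beyond the usual scatter, so compound 2 is the weaker inhibitor of the pair. The two compounds differ in more than one place, so no single step can be read between them.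

Compound 3 `O=C([C@H]1Cc2cc(Cl)cc(-c3ccnc4cc(Cn5cnccc5=O)sc34)c2O1)N1CCNCC1` differs from compound 2 in one place only: a group of 7 heavy atoms (4 carbon, 2 nitrogen, 1 oxygen; one six-membered aromatic ring with 2 hetero atoms) in place of one oxygen atom, on a saturated chain carbon bound to an aromatic carbon. Going by the values given here, no measured pair isolates this change. Among the compounds with values here, the only hint comes from compound 1, which also carries a larger group on a saturated chain carbon bound to an aromatic carbon instead of a hydroxy group, alongside other differences, and gives 3.4 nM. On that basis a moderate step to a lower number in this assay is expected, a 2.9-fold lower number from compound 2 to compound 3 (0.46 log units; beyond the scatter), though with wide uncertainty. For compound 3 the estimate in this assay is 15 nM, expected to fall between 4 nM and 60 nM.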

Compound 3, half-maximal inhibitory concentration: 27 nM
The estimate for compound 3 lay 1.8-fold (0.26 log units) below the measured number, within the range that was stated.
By their numbers in this assay, from the lowest: compound 1; then compounds 3 and 2 (each within the scatter of the next).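

In this assay, replacing the hydroxy group with a group of 7 heavy atoms that brings one six-membered aromatic ring with 2 hetero atoms, on a saturated chain carbon bound to an aromatic carbon, gives a 1.6-fold lower number from compound 2 to compound 3 (0.20 log units; within the scatter). Going by these compounds alone, this is the first single-place reading at this position, and it shows that the much larger group leaves the number within the scatter, even though the 1 hydrogen-bond donor of the hydroxy group is gone and the entering group has 3 hydrogen-bond acceptors. Nothing measured in these compounds explains why the two numbers lie so close.

This single exchange cannot show how far the position's indifference extends, since an amine, a carboxylic acid or a longer chain on the same carbon could read differently. It also leaves open whether the hetero atoms of the entering ring matter, which a plain phenyl ring in the same place would test.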